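The compounds below may be only part of what the source reports. "The series", "measured", "known", "first", "only" and "open" are said of these compounds alone.

Measured so far:
compound 1 `Cc1c(OCCCCOc2ccc(C(=O)O)cc2Cl)ccc(C(=O)CC2CCCC2)c1O` — 82.2%
compound 2 `CC(=O)c1ccc(OCCCCOc2ccc(C(=O)O)cc2C)c(C)c1O` — 83.1%

In an assay on HEK293 cells for positive allosteric modulation of metabotropic glutamate receptor 2 (Rattus norvegicus), read by thallium flux, with a stated time of 2.5 min (on this read-out lower numbers stand for smaller maximal responses and higher numbers for larger maximal responses), compound 1 gives 82.2%, the lower of the two numbers, while compound 2 gives 83.1%; the two lie within the scatter of each other, so nothing separates them. Among the measured compounds shown here, no step between measured compounds is available to guide the next one.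

Compound 3 `Cc1c(OCCCCOc2ccc(C(=O)O)cc2F)ccc(C(=O)CC2CCCC2)c1O` differs from compound 1 by fluoro in place of chloro on an aromatic carbon. Nothing in the two measured compounds suggests a shift beyond the scatter, so the step from compound 1 to compound 3 is expected to be small, a number 0.2 percentage points lower from compound 1 to compound 3 (within the scatter), in no particular direction. Compound 3 is estimated at 82%, with a range from 70% to 93%.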

Compound 3, largest response reached (reported as percent of maximum), in percent of the reference or control that the assay uses: 83.8%
Estimate against measurement, compound 3: 1.8 percentage points below; measured number inside the range.
By their numbers in this assay, from the lowest: compounds 1, 2 and 3 (each within the scatter of the next).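

Fluoro in place of chloro on this aromatic carbon, ortho to a large group and meta to a carboxy group, gives a number 1.6 percentage points higher from compound 1 to compound 3 (within the scatter) in this assay. Among the compounds shown here, with the rest of compound 1 held fixed, this position accepts either halogen without a change beyond the scatter, a direct comparison that the earlier compounds did not offer. Nothing available explains this result. As far as these compounds go, it remains open whether a methoxy group or an amine on this carbon would move the maximal response beyond the scatter.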